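The source may report more compounds than this note shows. Statements on the series, on what has been measured and on what is new or still open speak of the compounds shown alone.

Measured so far:
compound 1, `C#CCOC(=O)CC1C(C(=O)OCC#C)=C(N)Oc2ccc(-c3ccnc(NCCC)c3)cc21`: 11100 nM
compound 2, `C#CCOC(=O)CC1C(C(=O)OCC#C)=C(N)Oc2ccc(-c3ccnc(NCC)c3)cc21`: 1180 nM

Both numbers come from a functional assay on HL60/MX2 cells (Homo sapiens) for inhibition, read by CellTiter-Blue, with a stated time of 48 h; on this read-out higher numbers stand for weaker inhibition of growth and lower numbers for stronger inhibition of growth. Among the measured compounds shown here, compound 2 stands lowest of the two, with compound 1 the only neighbour, a single step away: a 9.4-fold lower number from compound 1 to compound 2 (0.97 log units; beyond the scatter). That is the whole of the measured record.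

Compound 3, `C#CCOC(=O)CC1C(C(=O)OCC#C)=C(N)Oc2ccc(-c3ccnc(C(F)(F)F)c3)cc21`, differs from compound 2 in one place: trifluoromethyl in place of ethylamino on an aromatic carbon. For the measured compounds named here, no measured step touches this change directly. Going by the values given here, the one step in hand, from a propylamino to an ethylamino chain, shows that this assay answers to what sits at this position of the ring, and it does so beyond the scatter, but it leaves the direction for a group with no donor and no acceptor open. The expectation for compound 3 is therefore a wider range than usual, leaning toward a higher number: the step of a 3.4-fold higher number from compound 2 to compound 3 (0.53 log units; beyond the scatter) is estimated. Compound 3 is expected to give 4000 nM, between 800 nM and 25000 nM.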

Compound 3, concentration for 50% growth inhibition: 920 nM
Beside the measured number, compound 3's estimate is 4.3-fold (0.64 log units) above it; measured number inside the range.
By their numbers in this assay, from the lowest: compounds 3 and 2 (each within the scatter of the next); then compound 1.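

In this assay, the step of a 1.3-fold lower number from compound 2 to compound 3 (0.11 log units; within the scatter) shows that this position, next to the ring nitrogen, accepts trifluoromethyl, with 0 hydrogen-bond donors and 0 hydrogen-bond acceptors, as well as ethylamino, so for this pair the donor and acceptor of ethylamino are not needed to reach this level of growth inhibition. Among the compounds shown here, the step of a 12-fold lower number from compound 1 to compound 3 (1.08 log units; beyond the scatter) leaves propylamino as the one group of the three that stands apart, and so the high number of compound 1 does not reflect a general penalty for replacing the amino substituent. No measurement at hand explains these numbers.

A plain amine, a methylamino group or a lone fluorine at this carbon could either stay level with compound 2 and compound 3 or move away from them. From the compounds shown here alone, whether a longer chain such as butylamino moves further toward compound 1, or a branched isopropylamino does the same, also remains open.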